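Swapping an aryl imine for a cinnamyl imine on a shared core

The compounds below may be only part of what the source reports. "The series", "measured", "known", "first", "only" and "open" are said of these compounds alone.

Of the compounds shown here, three built on one shared core have been tested in an ADME assay on HeLa cells (Homo sapiens) for cytotoxicity, read by MTT assay, with a stated time of 72 h; a lower number here means that less compound is tolerated, a higher number that more compound is tolerated. Compound 1 `Nc1sc2c(c1-c1nc3ccccc3s1)CCCC2` carries a free amine and gives 475 ug/mL. Compound 2 `Fc1ccccc1/C=N/c1sc2c(c1-c1nc3ccccc3s1)CCCC2` turns that amine into an imine bearing a 2-fluorophenyl group and gives 426 ug/mL. Compound 3 `COc1cc(/C=N/c2sc3c(c2-c2nc4ccccc4s2)CCCC3)cc(OC)c1OC` carries a trimethoxyphenyl imine instead and gives 448 ug/mL. The change a 1.1-fold lower number from compound 1 to compound 2 (0.05 log units; within the scatter) stays within the scatter, and the gaps between compound 2 and its two neighbours are just as small, so on these numbers compound 2 cannot be told apart from either compound 1 or compound 3; all three sit at roughly the same level.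

Compound 4 `C(=C/c1ccccc1)\C=N\c1sc2c(c1-c1nc3ccccc3s1)CCCC2` is not yet measured. It differs from compound 2 as follows: 2-phenylethenyl in place of 2-fluorophenyl on a carbon with a double bond to nitrogen. Within the data shown here, the only measured step that touches this position, a 1.1-fold lower number from compound 1 to compound 2 (0.05 log units; within the scatter), stayed within the scatter, and compound 3 shows that a different aryl group on the imine also leaves the number unchanged. Nothing here suggests that the 2-phenylethenyl group would behave differently, so the step from compound 2 to compound 4 is expected to be a 1.0-fold higher number from compound 2 to compound 4 (0.00 log units; within the scatter), meaning no shift beyond the scatter. Compound 4 is therefore estimated at 430 ug/mL, with a likely range from 250 ug/mL to 650 ug/mL.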

Compound 4, half-maximal cytotoxic concentration: 389 ug/mL
Beside the measured number, compound 4's estimate is 1.1-fold (0.04 log units) above it; the range from low to high includes it.
By their numbers in this assay, from the lowest: compounds 4, 2, 3 and 1 (each within the scatter of the next).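

In this assay, putting 2-phenylethenyl in place of 2-fluorophenyl on the carbon with a double bond to nitrogen gives a 1.1-fold lower number from compound 2 to compound 4 (0.04 log units; within the scatter), so this further change at the same place also leaves the number unmoved. The earlier imines, compound 2 and compound 3, carried only substituted phenyl groups here, whereas compound 4 brings in a double bond outside aromatic rings and has no fluorine, and even this different kind of group stays within the scatter. No measurement available here offers an explanation for this flat result.

None of the four compounds shown differs from the others beyond the scatter, so what could shift this number remains unknown. As far as these compounds go, it remains open whether a group of another kind on this carbon, such as a carboxylic acid or a long saturated carbon chain, would stay at the same level, or whether a hydroxyl group on the ring of the 2-phenylethenyl group would change the picture.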